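This account rests on a few compounds, and the source may have more. Where it says the series, first, only, none or still open, it means among the compounds named here.

Measured compounds in a functional assay on the whole organism for antagonist activity, with Mus musculus as the target; on this read-out lower numbers stand for an effect already at smaller amounts and higher numbers for an effect only at larger amounts of compound:
compound 1, `COc1cc(N)c(Cl)cc1NC(=O)C1CCN(CC2CC2)CC1`: > 10 mg/kg
compound 2, `COc1cc(N)c(Cl)cc1NC(=O)C1CCN(Cc2ccc(Cl)cc2)CC1`: 1.2 mg/kg

Compound 1 sits at the limit of > 10 mg/kg in this assay, at which 1 of the 2 values shown sits, which is a limit of this assay and not a number. Among the compounds with values here, compound 2 therefore stands as the only measured number of the pair, with nothing else to compare it against on the same footing.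

Compound 3, `COc1cc(N)c(Cl)cc1NC(=O)C1CCN(Cc2cccc(C#N)c2)CC1`, has not yet been measured. It differs from compound 2 in one place: 3-cyanophenyl in place of 4-chlorophenyl on a saturated chain carbon bound to an amine nitrogen in a ring. Within the data shown here, the single measured step, an at least 8.3-fold lower number from compound 1 to compound 2 (0.92 log units; beyond the scatter), replaced a small saturated ring with an aromatic ring at that same place and lowered the number clearly. Among the measured compounds shown here, the step to compound 3 keeps the aromatic ring and changes only what sits on it, so that measured step gives only loose guidance; no measured step shows what a 3-cyanophenyl in place of a 4-chlorophenyl does here. The expectation is therefore a step no larger than modest, a 1.7-fold higher number from compound 2 to compound 3 (0.22 log units; within the scatter), with its direction uncertain. Compound 3 is estimated at 2 mg/kg in this assay, within a range from 0.6 mg/kg to 8 mg/kg.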

Compound 3, dose for half-maximal effect: > 4 mg/kg
Compound 3: a limit, no number; the forecaster's own chance of this, stated with the estimate: 15%; middle value at least 2.0-fold (0.30 log units) away from the limit.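

In this assay, compound 3 carries a limit and not a number: the limit of > 4 mg/kg in this assay, at which 1 of the 3 values shown sits. That limit can still be read as a step, and it is beyond the scatter: an at least 3.3-fold higher number from compound 2 to compound 3 (0.52 log units; beyond the scatter). The earlier compounds shown here showed only that 4-chlorophenyl gave a lower number than cyclopropyl on this saturated chain carbon bound to an amine nitrogen in a ring; this result adds that keeping an aromatic ring at this place is not enough to hold that low number, and that what the ring carries matters here.

The step between compound 1 and compound 3 cannot be read, and the change from 4-chlorobenzyl to 3-cyanobenzyl swaps the group on the ring and its place on the ring together, so the compounds shown cannot tell which of the two counts. A 4-cyanophenyl or a 3-chlorophenyl at this place would separate those two changes, and a plain unsubstituted phenyl would show what the ring does without either group.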